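A Ring Swap on Compound 3

The source may report more compounds than this note shows. Statements on the series, on what has been measured and on what is new or still open speak of the compounds shown alone.

Of the compounds shown here, three have been measured so far in an ADME assay on microsomes from liver (Rattus norvegicus, strain Sprague-Dawley) for metabolic stability, read by HPLC, using NADPH, with stated times of 5 min and 60 min, tested at 10 uM; on this read-out lower numbers stand for a shorter-lived compound and higher numbers for a longer-lived compound. Compound 1 `CC(C)(C)c1ccc(C(=O)NCc2ccc(NS(=O)(=O)C(F)(F)F)cc2Cl)cc1` gives 1.3 h, compound 2 `CC(C)(C)c1ccc(C(=O)NCc2c(Cl)cc(NS(C)(=O)=O)cc2Cl)cc1` gives 1.37 h, and compound 3 `CS(=O)(=O)Nc1ccc(CNC(=O)c2ccc(C34CC(C3)C4)cc2)c(Cl)c1` gives 1.35 h. Compound 3 has no real separation from the other two, since its number lies within the usual scatter of both. Repeat measurements could not be expected to tell these three apart.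

Compound 4 `CS(=O)(=O)Nc1ccc(CNC(=O)c2ccc(N3CCCC3)cc2)c(Cl)c1` has not yet been measured. It keeps the rest of compound 3 and exchanges one group: a group of 5 heavy atoms (4 carbon, 1 nitrogen; one five-membered non-aromatic ring with 1 hetero atom) in place of a group of 5 heavy atoms (5 carbon; 2 four-membered non-aromatic rings of carbon only), on an aromatic carbon. The incoming pyrrolidin-1-yl sits on an aromatic carbon, para to a large group.

Within the data shown here, no two measured compounds differ in only one place, so the data offer no direct measure of such a swap in this assay. The nearest hint is indirect: compound 1 at 1.3 h and compound 3 at 1.35 h carry different groups here, among other differences, yet remain within the scatter of each other. Only a small downward step is therefore expected, and the downward direction is a cautious judgement rather than a measured trend. The estimated change is a 1.4-fold lower number from compound 3 to compound 4 (0.13 log units; within the scatter), which would stay within the scatter. For compound 4 the expected half-life is 1 h, with an estimated range from 0.45 h to 1.9 h.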

Compound 4, half-life: 1.28 h
Compound 4: middle estimate off by 1.3-fold (0.11 log units), on the low side, and the stated range covers the measured number.
By their numbers in this assay, from the lowest: compounds 4, 1, 3 and 2 (each within the scatter of the next).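

In this assay, among these compounds, putting pyrrolidin-1-yl in place of the group built from 2 four-membered non-aromatic rings of carbon only gives a 1.1-fold lower number from compound 3 to compound 4 (0.02 log units; within the scatter) and is the first direct reading of a single change in this set. At this place, on an aromatic carbon of a six-membered aromatic ring of carbon only and para to a large group, the read-out does not tell apart an all-carbon group and a ring that brings in 1 nitrogen and 1 hydrogen-bond acceptor, even though both have 5 heavy atoms. Nothing measured here explains this result.

Among the compounds shown here, this single step covers only one exchange on the core of compound 3, so it cannot show that the position tolerates every change in this way. The compounds shown leave open whether a carboxylic acid, a primary amine or a longer carbon chain at this place would shift the half-life beyond the scatter, and whether pyrrolidin-1-yl would behave the same way on a core carrying a different group on the sulfonamide.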